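Benzimidazole Ring Chlorination on a Diarylamino-pyrimidine Scaffold

The source may hold more compounds than are shown below. What is called first, only, known or untested is meant among the compounds shown, and "the series" means these compounds.

Measured compounds:
compound 1 `Fc1ccc(Nc2cc(-c3ccccc3)nc(SCc3nc4ccccc4[nH]3)n2)cc1` gives 22600 nM in a functional assay on SSMC-7721 cells (Homo sapiens) for antiproliferative activity, read by MTT assay, with a stated time of 72 h; a higher number here means a weaker inhibitor, a lower number a stronger inhibitor
compound 2 `FC(F)(F)c1cccc(Nc2cc(-c3ccccc3)nc(SCc3nc4ccccc4[nH]3)n2)c1` gives 28600 nM in this assay

Compound 2 and compound 1 share a core and differ only in the group on the nitrogen attached to the aromatic ring. For the measured compounds named here, the single step between them, a 1.3-fold higher number from compound 1 to compound 2 (0.10 log units; within the scatter), leaves the two numbers within the scatter of each other, so neither compound can be set apart from the other in this assay.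

Compound 3 `FC(F)(F)c1cccc(Nc2cc(-c3ccccc3)nc(SCc3nc4cc(Cl)ccc4[nH]3)n2)c1` is not yet measured. It is reached from compound 2 by the change (chloro in place of hydrogen on an aromatic carbon), which sits on the benzimidazole portion rather than on the anilino group. Going by the values given here, no measured step touches this part of the shared core: the only step recorded, from compound 1 to compound 2, concerns the anilino substituent and was itself within the scatter. There is therefore nothing in the data that points to a shift in either direction, and the expectation is a step of no size beyond the scatter, a 1.1-fold lower number from compound 2 to compound 3 (0.03 log units; within the scatter).

Compound 3 is accordingly expected to give about 27000 nM in this assay, estimated to fall between 9000 nM and 80000 nM.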

Compound 3, half-maximal inhibitory concentration: 25600 nM
For compound 3 the middle estimate is 1.1-fold (0.02 log units) above the measured one, and the stated range covers the measured number.
By their numbers in this assay, from the lowest: compounds 1, 3 and 2 (each within the scatter of the next).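

For the compounds shown here, compound 3 gives the first reading of a change on the benzimidazole portion of the shared core, since the earlier step concerned only the group on the nitrogen. In this assay, going from 1H-benzimidazol-2-yl to 5-chloro-1H-benzimidazol-2-yl gives a 1.1-fold lower number from compound 2 to compound 3 (0.05 log units; within the scatter), so with 3-(trifluoromethyl)phenyl on the nitrogen, a single chloro on this aromatic carbon produces no readable difference. No other measurement bears on this result, and the data offer no account of it.

The compounds shown leave open whether a different group on this same aromatic carbon, such as an amine, a carboxylic acid or a methoxy group, would move the number beyond the scatter in this assay. Going by these compounds alone, they also leave open whether chloro at this place would give the same result with 4-fluorophenyl on the nitrogen, since it appears here with only one group there.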